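A few compounds are considered here, and "the series" means these few. Any claim that something is new, unique, unknown or untested is made for them only; others in the source may bear on it.

In a functional assay on A2780 cells (Homo sapiens) for antiproliferative activity, read by MTT assay, with a stated time of 48 h (a higher number here means a weaker inhibitor, a lower number a stronger inhibitor), two compounds have been measured so far:

- compound 1 `COc1ccc(-c2cc3c(cn2)[nH]c(=O)n3-c2cc(OC)c(OC)c(OC)c2)cc1`: 930 nM
- compound 2 `CCOc1ccc(-c2cc3c(cn2)[nH]c(=O)n3-c2cc(OC)c(OC)c(OC)c2)cc1`: 2980 nM

Compound 2 has the higher number of the two, so it is the weaker inhibitor. Compound 3 `COc1ccc(-c2cc3c(cn2)[nH]c(=O)n3-c2cc(OC)c(OC)c(OC)c2)cc1C` has the same atoms as compound 2, joined differently: 4-methoxy-3-methylphenyl in place of 4-ethoxyphenyl on an aromatic carbon. In words, 4-methoxy-3-methylphenyl stands in place of 4-ethoxyphenyl on an aromatic carbon. Among the compounds with values here, only one measured step bears on this, a 3.2-fold higher number from compound 1 to compound 2 (0.51 log units; beyond the scatter), a modest change beyond the scatter that came with lengthening the methoxy group to ethoxy. Within the data shown here, compound 3 keeps the methoxy group of compound 1, which gives 930 nM, but no measured compound shows what a methyl group on that ring does. A modest move toward a lower number is therefore expected, a 2.3-fold lower number from compound 2 to compound 3 (0.36 log units; beyond the scatter). For compound 3, the estimate is 1300 nM, with an expected range of 350 nM to 4500 nM.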

Compound 3, half-maximal inhibitory concentration: 1530 nM
Compound 3: middle estimate off by 1.2-fold (0.07 log units), on the low side, and the stated range covers the measured number.
By their numbers in this assay, from the lowest: compounds 1, 3 and 2 (each within the scatter of the next, the first and the last beyond it).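

In this assay, 4-methoxy-3-methylphenyl in place of 4-ethoxyphenyl gives a 1.9-fold lower number from compound 2 to compound 3 (0.29 log units; within the scatter), and the added ring methyl alone gives a 1.6-fold higher number from compound 1 to compound 3 (0.22 log units; within the scatter), so neither step separates compound 3 from its neighbour beyond the scatter. The ring methyl is thus the first change on this aryl group shown to stay within the scatter, unlike the lengthening of methoxy to ethoxy, which gave a 3.2-fold higher number from compound 1 to compound 2 (0.51 log units; beyond the scatter) and remains the only step here beyond it. Nothing available accounts for the difference between these changes.

The compounds shown leave open whether a chlorine, a hydroxyl or an amine on that same ring carbon would also stay within the scatter. They also leave open whether a longer chain such as propoxy would carry the number further in the direction that ethoxy took it.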